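Cytotoxicity of a Shared Core Without Its Aromatic Ring

This account rests on a few compounds, and the source may have more. Where it says the series, first, only, none or still open, it means among the compounds named here.

Measured in an ADME assay on L6 cells (Rattus norvegicus) for cytotoxicity, read by resazurin assay, with a stated time of 70 h; a higher number here means a weaker inhibitor, a lower number a stronger inhibitor:
- Compound 1 `CC(=O)Oc1ccc2c(c1)C(C)=CC(C)(C)N2Cc1ccc(Cl)c(Cl)c1`: 28000 nM
- Compound 2 `COc1cccc(CN2c3ccc(OC(C)=O)cc3C(C)=CC2(C)C)c1`: 29000 nM

In this assay, compound 2 at 29000 nM sits within the scatter of compound 1. Compound 3 `CC(=O)Oc1ccc2c(c1)C(C)=CC(C)(C)N2C` differs from compound 2 by hydrogen in place of 3-methoxyphenyl on a saturated chain carbon bound to a nitrogen on an aromatic ring in a ring. Among the compounds with values here, the only measured step, a 1.0-fold higher number from compound 1 to compound 2 (0.02 log units; within the scatter), exchanges one substituted phenyl for another, so losing the ring altogether remains untested. On that step, the expected change is none beyond the scatter, written as a 1.4-fold higher number from compound 2 to compound 3 (0.14 log units; within the scatter). For compound 3 the estimated value is 40000 nM, with an expected range of 14000 nM to 110000 nM.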

Compound 3, half-maximal inhibitory concentration: 41000 nM
Compound 3: the middle estimate sits 1.0-fold (0.01 log units) below what was measured; the range from low to high includes it.
By their numbers in this assay, from the lowest: compounds 1, 2 and 3 (each within the scatter of the next).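

Hydrogen in place of 3-methoxyphenyl on this saturated chain carbon stays within the scatter in this assay (a 1.4-fold higher number from compound 2 to compound 3 (0.15 log units; within the scatter)), and so does hydrogen in place of 3,4-dichlorophenyl (a 1.5-fold higher number from compound 1 to compound 3 (0.17 log units; within the scatter)). The earlier step exchanged one substituted phenyl for another, whereas these steps show that at this position the shared core reads the same within the scatter with no aromatic ring at all. No data on the cause of this are given here. On these data alone, whether an amine, a carboxylic acid or a longer chain at this position would move the number beyond the scatter stays open.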